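A tert-butyl group added to compound 2

The source may report more compounds than this note shows. Statements on the series, on what has been measured and on what is new or still open speak of the compounds shown alone.

compound 1 `CCC1C[N+]2(c3ccnc4ccc(OC(C)CO)cc34)CCC1CC2` gives 2.31
compound 2 `OC(CC1CCCCN1)c1ccnc2ccccc12` gives 0.05

In a physicochemical assay for lipophilicity (on this read-out lower numbers stand for lower lipophilicity and higher numbers for higher lipophilicity), compound 2 stands lowest of the two measured compounds at 0.05, and compound 1 gives 2.31, a gap beyond the scatter. Among the compounds with values here, these two compounds differ in more than one place, so no measured single-place step guides the next estimate.

Compound 3 `CC(C)(C)c1cc(C(O)CC2CCCCN2)c2ccccc2n1` has not yet been measured. It differs from compound 2 by tert-butyl in place of hydrogen on an aromatic carbon, with tert-butyl in place of hydrogen on an aromatic carbon next to the ring nitrogen. Starting from compound 2 at 0.05, an upward move beyond the scatter is expected in this assay. The expected change is a number 1.55 log units higher from compound 2 to compound 3 (beyond the scatter). For compound 3 the estimated value is 1.6. The estimated range for compound 3 runs from 1 to 2.2.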

Compound 3, partition coefficient: 2.03
Beside the measured number, compound 3's estimate is 0.43 log units below it; the measured number falls inside the stated range.
By their numbers in this assay, from the lowest: compound 2; then compounds 3 and 1 (each within the scatter of the next).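

In this assay the replacement of hydrogen by tert-butyl on an aromatic carbon next to the ring nitrogen moves the number upward (a number 1.98 log units higher from compound 2 to compound 3 (beyond the scatter)). Within the data shown here, this is the first step in the set that changes only one place, so this position now has a measured read-out for a single group, something the gap between the two earlier compounds, which differ in more than one place, could not give. No supporting measurement bears on what lies behind the size of this step.

The compounds shown leave open how a methyl group, a trifluoromethyl group or an amine would read at this same aromatic carbon. They also leave open whether tert-butyl in place of hydrogen would give a step of similar size on the core of compound 1.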